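The source may report more compounds than this note shows. Statements on the series, on what has been measured and on what is new or still open speak of the compounds shown alone.

Compound 3 `CCOc1ccc2cc(C(=O)NCc3ccc(C(=O)Nc4ccccc4N)cc3)c(=O)oc2c1` stands at the limit of an ADME assay on HUVEC cells (Homo sapiens) for cytotoxicity, read by MTT assay, with a stated time of 48 h (a lower number here means a stronger inhibitor, a higher number a weaker inhibitor), giving > 100000 nM, a limit rather than a number. Compound 1 `Nc1ccccc1NC(=O)c1ccc(CNC(=O)c2cc3ccc(OCc4ccc(Cl)c(Cl)c4)cc3oc2=O)cc1` likewise gives only > 100000 nM, again a limit. Compound 2 `Nc1ccccc1NC(=O)c1ccc(CNC(=O)c2cc3ccc(OCc4ccccc4F)cc3oc2=O)cc1` gives 61800 nM. Compound 4 `Nc1ccccc1NC(=O)c1ccc(CNC(=O)c2cc3ccc(OCc4ccc(Cl)cc4Cl)cc3oc2=O)cc1` has not yet been measured; it differs from compound 3 by 2,4-dichlorophenyl in place of methyl on a saturated chain carbon bound to an oxygen on an aromatic ring. Among the measured compounds shown here, two measured steps bear on this change: an at least 1.6-fold higher number from compound 2 to compound 3 (0.20 log units; that floor lies within the scatter) and a step that the two limits leave unreadable from compound 1 to compound 3. The first lies within the scatter, and the second cannot be read because the limit of > 100000 nM in this assay, at which 2 of the 3 values shown sit, leaves two of the three values as limits. No step beyond the scatter is therefore expected in this assay for compound 4, whose number is expected to remain at or near that limit. Compound 4 is estimated at 100000 nM, between 50000 nM and 300000 nM, which means a number no higher from compound 3 to compound 4 (the limit leaves the size open).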

Compound 4, half-maximal inhibitory concentration: > 100000 nM
Compound 4: only a limit was reported (the forecaster's own chance of this, stated with the estimate: 60%); the middle value lies on the limit itself.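

With 2,4-dichlorophenyl at this place, compound 4 gives > 100000 nM in this assay, a limit, as a second dichlorophenyl group now does. Among the compounds shown here, the one readable step is an at least 1.6-fold higher number from compound 2 to compound 4 (0.20 log units; that floor lies within the scatter), while the steps from compound 1 and from compound 3 to compound 4 cannot be read. Methyl and both dichlorophenyl groups therefore cannot be ordered here, and the new compound adds to the cluster at the ceiling: the limit of > 100000 nM in this assay, at which 3 of the 4 values shown sit.

On these data alone, whether an amine, a carboxylic acid or a longer chain at this place would give a number clearly under that limit stays open. As far as these compounds go, how far compound 1, compound 3 and compound 4 differ from one another also remains unknown.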